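Replacing trifluoromethylphenyl with 4-hydroxyphenyl

The source may report more compounds than this note shows. Statements on the series, on what has been measured and on what is new or still open speak of the compounds shown alone.

Measured in a functional assay on MIA PaCa-2 cells (Homo sapiens) for inhibition, read by MTT assay, with a stated time of 72 h; a lower number here means a stronger inhibitor, a higher number a weaker inhibitor:
Compound 1 `COc1cc(NC(C)CCCNC(=O)Nc2cccc(O)c2)c2ncccc2c1` gives 46000 nM
Compound 2 `COc1cc(NC(C)CCCNC(=O)NNC(=O)Nc2cccc(F)c2)c2ncccc2c1` gives 69000 nM
Compound 3 `COc1cc(NC(C)CCCNC(=O)Nc2cccc(C(F)(F)F)c2)c2ncccc2c1` gives 17000 nM

Compound 3 has the lowest number of the three, with compound 1 nearest and compound 2 furthest. Compound 4 `COc1cc(NC(C)CCCNC(=O)Nc2ccc(O)cc2)c2ncccc2c1`, not yet measured, carries 4-hydroxyphenyl in place of 3-(trifluoromethyl)phenyl on an amide-type nitrogen. The closest measured step is a 2.7-fold lower number from compound 1 to compound 3 (0.43 log units; beyond the scatter), with trifluoromethyl in place of hydroxy on an aromatic carbon. Read in reverse, it points towards a higher number for a hydroxyphenyl compound. Within the data shown here, compound 1 carries 3-hydroxyphenyl rather than 4-hydroxyphenyl, however, and no measured pair shows what that difference does. The other step reaching compound 3, a 4.1-fold lower number from compound 2 to compound 3 (0.61 log units; beyond the scatter), involves a different replacement and bears on this change less directly. A modest step towards a higher number is therefore expected in this assay. The estimated step is a 2.5-fold higher number from compound 3 to compound 4 (0.39 log units; beyond the scatter). For compound 4 the estimate is 42000 nM, with an expected range from 18000 nM to 95000 nM.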

Compound 4, half-maximal inhibitory concentration: 57000 nM
Compound 4: middle estimate off by 1.4-fold (0.13 log units), on the low side, within the range that was stated.
By their numbers in this assay, from the lowest: compound 3; then compounds 1, 4 and 2 (each within the scatter of the next).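

Measured in this assay the two hydroxyphenyl compounds now form a pair, and a 1.2-fold higher number from compound 1 to compound 4 (0.09 log units; within the scatter) shows that 4-hydroxyphenyl and 3-hydroxyphenyl on this amide-type nitrogen cannot be told apart. The 3-(trifluoromethyl)phenyl group thus keeps the lower number against either hydroxyphenyl group, with a 3.4-fold higher number from compound 3 to compound 4 (0.53 log units; beyond the scatter) for this change, whereas 4-hydroxyphenyl in place of ((3-fluorophenyl)carbamoyl)amino gives a 1.2-fold lower number from compound 2 to compound 4 (0.08 log units; within the scatter) and so makes no clear difference. Nothing available accounts for these differences.

The compounds shown leave open whether an amine or a carboxylic acid in place of the hydroxy group would give a number different from those of the hydroxyphenyl compounds. They also leave open whether a methyl or chloro group in place of trifluoromethyl would retain the lower number of compound 3.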